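A Second Methyl on the Piperidine Ring

This account rests on a few compounds, and the source may have more. Where it says the series, first, only, none or still open, it means among the compounds named here.

Measured so far:
compound 1, `CC(C)CNCC(=O)N1N=C(c2cc3ccccc3oc2=O)CC1c1ccccc1`: 1920 nM
compound 2, `CC1CCCN(CC(=O)N2N=C(c3cc4ccccc4oc3=O)CC2c2ccccc2)C1`: 28300 nM

Both were tested in a functional assay on PC-3 cells (Homo sapiens) for cytotoxicity, read by MTT assay, with a stated time of 48 h; on this read-out lower numbers stand for stronger inhibition and higher numbers for weaker inhibition. Among the measured compounds shown here, compound 2 gives the highest of the two numbers, and its only neighbour is compound 1, separated by the single step of a 15-fold higher number from compound 1 to compound 2 (1.17 log units; beyond the scatter), in which an open isobutylamino chain became a 3-methylpiperidin-1-yl ring on the carbon bound to the carbonyl. Compound 3 `CC1CC(C)CN(CC(=O)N2N=C(c3cc4ccccc4oc3=O)CC2c2ccccc2)C1` differs from compound 2 by methyl in place of hydrogen on a saturated ring carbon, read one bond further out as 3-methylpiperidin-1-yl becoming 3,5-dimethylpiperidin-1-yl. For the measured compounds named here, no measured step adds a methyl to a saturated ring carbon, and the one known step concerns a different kind of change, so it gives no direct guide. With nothing pointing either way, compound 3 is expected to stay close to compound 2 in this assay, a step of about a 1.1-fold higher number from compound 2 to compound 3 (0.03 log units; within the scatter) that need not reach beyond the scatter. The estimate for compound 3 is 30000 nM, within a range from 10000 nM to 90000 nM.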

Compound 3, half-maximal inhibitory concentration: "not active" (no number reported)
The entry for compound 3 holds no number, and the estimate cannot be compared.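

Among the compounds shown here, compound 3 is recorded as "not active" with no number, so no step from compound 2 to compound 3 can be read. No supporting evidence bears on this entry. On these data alone, how far the 3,5-dimethylpiperidin-1-yl group shifts the number from that of compound 2 stays open.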